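The compounds below may be only part of what the source reports. "The series", "measured", "known", "first", "only" and "open" are said of these compounds alone.

Working notes on the series. Compound 1 `C[C@@H](Nc1c(C(=O)NCc2ccc(F)cc2)nc(Br)c2cccnc12)c1ccccc1` carries a (1-phenylethyl)amino group on the shared core; for compound 1 the result in a functional assay on MCF7 cells (Homo sapiens) for cytotoxicity, read by MTT assay, with a stated time of 72 h (a lower number here means a stronger inhibitor, a higher number a weaker inhibitor), stands as "not determined" (no result reported), so compound 1 has no number to stand on. Compound 2 `N[C@H]1CC[C@H](Nc2c(C(=O)NCc3ccco3)nc(Br)c3cccnc23)CC1` likewise shows "not determined" (no result reported) in this assay. Among the measured compounds shown here, the only number in the set comes from compound 3 `N[C@H]1CC[C@H](Nc2c(C(=O)NCc3cccc(C(F)(F)F)c3)nc(Br)c3cccnc23)CC1`, which in this assay gives 15000 nM, a weak effect.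

Compound 4 `O=C(NCc1ccc(F)cc1)c1nc(Br)c2cccnc2c1N1CCNCC1` is the next candidate; it differs from compound 1 in one place, (piperazin-1-yl in place of (1-phenylethyl)amino on an aromatic carbon). For the measured compounds named here, with no measured step on record between compound 1 and compound 4, the size of the step cannot be read from the data; the expectation is a result of the same weak order as compound 3 with 15000 nM, and nothing beyond the scatter can be claimed in either direction. Compound 4 is thus estimated at 20000 nM in this assay, with a range from 5000 nM to 60000 nM, and a real chance that only a limit is reported.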

Compound 4, half-maximal inhibitory concentration: 7000 nM
Beside the measured number, compound 4's estimate is 2.9-fold (0.46 log units) above it, within the range that was stated.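

In this assay compound 1 stands as "not determined" (no result reported) and compound 4 gives 7000 nM so no step can be read between the two. Nothing on record bears on a cause for this result. What the compounds shown leave open is how piperazin-1-yl and (1-phenylethyl)amino compare on the shared core in this assay.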